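A few compounds are considered here, and "the series" means these few. Any claim that something is new, unique, unknown or untested is made for them only; others in the source may bear on it.

Three compounds have been measured in a functional assay on DU-145 cells (Homo sapiens) for inhibition, read by trypan blue exclusion, with a stated time of 96 h; on this read-out higher numbers stand for weaker inhibition of growth and lower numbers for stronger inhibition of growth:

- compound 1 `Cc1ccc(CS(=O)(=O)/C(=C/c2ccccc2OCc2ccccc2)C(=O)c2ccc(Cl)cc2)cc1` gives 1000 nM
- compound 2 `O=C(/C(=C\c1ccccc1OCc1ccccc1)S(=O)(=O)c1ccc(F)cc1)c1ccc(Cl)cc1` gives 1000 nM
- compound 3 `O=C(/C(=C\c1ccccc1OCc1ccccc1)SCc1ccc(Cl)c(Cl)c1)c1ccc(Cl)cc1` gives 10000 nM

At 10000 nM, compound 3 has the highest number of the three and so the weakest growth inhibition. Compound 4 `Cc1ccc(CS/C(=C/c2ccccc2OCc2ccccc2)C(=O)c2ccc(Cl)cc2)cc1` has not yet been measured. It differs from compound 3 in one place, with 4-methylphenyl in place of 3,4-dichlorophenyl on a saturated chain carbon bound to a sulfur.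

The two largest measured steps, a 10-fold higher number from compound 1 to compound 3 (1.00 log units; beyond the scatter) and a 10-fold higher number from compound 2 to compound 3 (1.00 log units; beyond the scatter), both replace a sulfonyl group with a sulfanyl group, whereas compound 3 and compound 4 are both sulfanyl compounds. These steps therefore bear on the change only indirectly. For the measured compounds named here, the closest evidence is no change at the digits printed from compound 1 to compound 2 (within the scatter), although that swap sits on a sulfonyl sulfur and no step between two sulfanyl compounds has been measured. On this single precedent, no shift beyond the scatter is expected in this assay. The expected step is no change at the digits printed from compound 3 to compound 4 (within the scatter). For compound 4 the estimated value is 10000 nM, with an expected range from 3000 nM to 30000 nM.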

Compound 4, concentration for 50% growth inhibition: 1000 nM
Estimate against measurement, compound 4: 10-fold (1.00 log units) above; the measured number lies below the stated range.
By their numbers in this assay, from the lowest: compounds 1, 2 and 4 (each within the scatter of the next); then compound 3.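

Among the sulfanyl compounds, the group on the saturated chain carbon bound to a sulfur does matter in this assay: 4-methylphenyl in place of 3,4-dichlorophenyl shows a 10-fold lower number from compound 3 to compound 4 (1.00 log units; beyond the scatter), a sensitivity the swap on the sulfonyl sulfur had not shown. With the 4-methylbenzyl group held fixed, (4-methylbenzyl)sulfanyl in place of (4-methylbenzyl)sulfonyl shows no change at the digits printed from compound 1 to compound 4 (within the scatter), and the comparison with the (4-fluorophenyl)sulfonyl group shows no change at the digits printed from compound 2 to compound 4 (within the scatter), so a sulfanyl group does not by itself bring the higher number of compound 3. Nothing available accounts for the step between the two sulfanyl compounds.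

Still open, from the compounds shown here alone, is whether a single chlorine, an amine or a carboxylic acid on that phenyl ring would track compound 3 or compound 4. Also open, going by these compounds, is whether a (3,4-dichlorobenzyl)sulfonyl group would match the sulfonyl compounds or compound 3.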